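One Added Methyl on the 1-Methoxyethyl Group

This account rests on a few compounds, and the source may have more. Where it says the series, first, only, none or still open, it means among the compounds named here.

In a functional assay on OCI-Ly3 cells (Homo sapiens) for antiproliferative activity (on this read-out higher numbers stand for an effect only at larger amounts of compound and lower numbers for an effect already at smaller amounts), compound 1 `O=C(Nc1cnc(-n2nccn2)c(Cl)c1)Nc1cnc2ccc(F)cc2c1C1CC1`, which carries a cyclopropyl group, gives 720 nM. Within the data shown here, compound 2 `COC(C)c1c(NC(=O)Nc2cnc(-n3nccn3)c(Cl)c2)cnc2ccc(F)cc12`, with 1-methoxyethyl in place of that cyclopropyl on an aromatic carbon, gives 270 nM, the lower of the two numbers measured so far. The change between them is a 2.7-fold lower number from compound 1 to compound 2 (0.43 log units; beyond the scatter), a modest step beyond the scatter.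

Compound 3 `COC(C)(C)c1c(NC(=O)Nc2cnc(-n3nccn3)c(Cl)c2)cnc2ccc(F)cc12` has not yet been measured. It differs from compound 2 in one place: methyl in place of hydrogen on a saturated chain carbon bound to an aromatic carbon, an oxygen on a saturated carbon and a saturated chain carbon. The 1-methoxyethyl group of compound 2 thus becomes 1-methoxy-1-methylethyl in compound 3.

Among the measured compounds shown here, only one measured step bears on this group, a 2.7-fold lower number from compound 1 to compound 2 (0.43 log units; beyond the scatter), and it exchanged the whole group rather than adding a single methyl. For the measured compounds named here, with that modest step as the only guide, no change beyond the scatter is expected in this assay. The expected step is a 1.1-fold lower number from compound 2 to compound 3 (0.03 log units; within the scatter). For compound 3 the estimated value is 250 nM, with an expected range of 90 nM to 700 nM.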

Compound 3, half-maximal effective concentration: 410 nM
For compound 3 the middle estimate is 1.6-fold (0.21 log units) below the measured one; measured number inside the range.
By their numbers in this assay, from the lowest: compounds 2, 3 and 1 (each within the scatter of the next, the first and the last beyond it).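

On the saturated chain carbon bound to an aromatic carbon, methyl in place of hydrogen gives a 1.5-fold higher number from compound 2 to compound 3 (0.18 log units; within the scatter) in this assay and so shows that this carbon takes the added methyl without a step beyond the scatter. Among these compounds, the earlier pair showed only that exchanging the whole group for cyclopropyl could move the number beyond the scatter, whereas 1-methoxy-1-methylethyl in place of cyclopropyl gives a 1.8-fold lower number from compound 1 to compound 3 (0.24 log units; within the scatter) and does not stand apart from compound 1 in the way compound 2 does. Nothing available here explains why these numbers fall as they do.

With compound 3 within the scatter of both compound 1 and compound 2, the compounds shown leave open whether the added methyl has any real effect at this carbon. They also leave open how an ethyl group in place of the added methyl, or a hydroxyl or an amine in place of the methoxy, would read in this assay on the shared core.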